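Shortening the chain count: one heptyl ether instead of two

The source may hold more compounds than are shown below. What is called first, only, known or untested is meant among the compounds shown, and "the series" means these compounds.

Compound 2 `CCCCCCCO[C@@H]1[C@@H](N)[C@@H](O[C@H]2[C@H](O)[C@@H](OCCCCCCC)[C@H](N)C[C@@H]2N)O[C@H](CN)[C@H]1O` gives the highest of the two numbers recorded in an ADME assay on J774 cells (Mus musculus) for cytotoxicity, read by MTT assay, with a stated time of 24 h, tested at 10 uM (a lower number here means a stronger effect, a higher number a weaker effect of the compound at the concentration tested), namely 96.3%, so at this concentration it shows the weaker effect of the pair. Its nearest neighbour on the numbers is compound 1 `CCCCCCCCCCCO[C@@H]1[C@@H](N)[C@@H](O[C@H]2[C@H](O)[C@@H](O)[C@H](N)C[C@@H]2N)O[C@H](CN)[C@H]1O`, which in this assay gives 81.8%, a gap that lies beyond the usual scatter. Compound 1 carries a single undecyl ether, compound 2 two heptyl ethers.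

Compound 3 `CCCCCCCO[C@@H]1[C@@H](N)[C@@H](O[C@H]2[C@H](O)[C@@H](O)[C@H](N)C[C@@H]2N)O[C@H](CN)[C@H]1O` has not yet been measured in this assay. It differs from compound 2 by hydrogen in place of heptyl on an oxygen on a saturated carbon, the same difference, cut one bond further out, reading heptyloxy to hydroxy; compound 3 thus keeps one heptyl ether.

Within the data shown here, no measured pair in this set shows the effect of this exact change, so any expectation rests on the two numbers alone. Compound 3 is expected to stay close to compound 2, with the step of a number 3.3 percentage points lower from compound 2 to compound 3 (within the scatter) estimated to fall within the scatter. For compound 3 the value in this assay is estimated at 93%, with a range from 78% to 105%.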

Compound 3, a percentage reported as activity, at one concentration (the size of the read-out at that concentration, not a potency): 77.5%
Compound 3: the middle estimate sits 15.5 percentage points above what was measured; measured number outside the range, below it.
By their numbers in this assay, from the lowest: compounds 3 and 1 (each within the scatter of the next); then compound 2.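

In this assay, among these compounds, the step of a number 18.8 percentage points lower from compound 2 to compound 3 (beyond the scatter) is the only measured change at this oxygen on a saturated carbon, and it shows that the change from heptyloxy to hydroxy there is not silent: it moves the read-out beyond the scatter, towards the stronger effect at the concentration tested. The chain on the remaining ether gives no such separation, since the step of a number 4.3 percentage points lower from compound 1 to compound 3 (within the scatter), for hydrogen in place of butyl on a saturated chain carbon, seven bonds along the chain from an oxygen on a saturated carbon, leaves the single heptyl ether and the single undecyl ether indistinguishable in this read-out. Nothing available accounts for either result.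

The compounds shown leave open how a benzyl ether or a shorter ethyl ether would read at this oxygen in place of heptyl, and whether a dodecyl or longer chain on the remaining ether would stay within the scatter of the undecyl ether. They also leave open whether a pair of ethers with chains longer than heptyl would read like the single ethers or like the pair of heptyl ethers.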